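This account rests on a few compounds, and the source may have more. Where it says the series, first, only, none or still open, it means among the compounds named here.

Compound 1, `CCOC(=O)c1oc2ccc(NS(=O)(=O)c3ccc(C(F)(F)F)cc3)cc2c1C`, gives 5030 nM in a functional assay on HCT-116 cells (Homo sapiens) for inhibition, read by MTT assay, with a stated time of 72 h; a lower number here means a stronger inhibitor, a higher number a weaker inhibitor.
Compound 2, `CCOC(=O)c1oc2ccc(N(Cc3ccccc3)S(=O)(=O)c3ccc(C)cc3)cc2c1C`, gives > 40000 nM in this assay.

Of the two measured compounds only compound 1 returns a number. For compound 2 the reported value is a limit of the assay and not a number: compound 2 stands at the limit of > 40000 nM in this assay, at which 1 of the 2 values shown sits, so how far its potency lies beyond that boundary is not known. Among the compounds with values here, the two compounds differ in more than one place, and no single-change step between them is available, so their two values can only be set side by side.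

Compound 3, `CCOC(=O)c1oc2ccc(N(Cc3ccccc3)S(=O)(=O)c3cccc(Cl)c3)cc2c1C`, has yet to be measured in this assay. It differs from compound 2 in one place: 3-chlorophenyl in place of 4-methylphenyl on a sulfonyl sulfur. Within the data shown here, no measured step in this set bears on such a change, and because compound 2 sits at the limit of > 40000 nM in this assay, at which 1 of the 2 values shown sits, there is no number to measure from. The change expected here is a number no higher from compound 2 to compound 3 (the limit leaves the size open), none beyond the usual scatter, with a real chance that only a limit is reported again. Compound 3 is expected to give about 40000 nM, in the range 8000 nM to 120000 nM.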

Compound 3, half-maximal inhibitory concentration: > 40000 nM
Compound 3 gave a limit, no number (the forecaster's own chance of this, stated with the estimate: 60%); the middle value sits exactly at the limit.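

Compound 3, like compound 2, is reported in this assay only as a limit and not as a number, so no step can be read between these two compounds: the limit of > 40000 nM in this assay, at which 2 of the 3 values shown sit.

The compounds shown leave open how far either one lies past that limit, and whether 3-chlorophenyl in place of 4-methylphenyl on a sulfonyl sulfur changes potency at all.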